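Loss of the Benzyl Ether on a Weak Aortic Inhibitor

The compounds below may be only part of what the source reports. "The series", "measured", "known", "first", "only" and "open" are said of these compounds alone.

In a functional assay on aorta (Rattus norvegicus) (on this read-out lower numbers stand for stronger inhibition and higher numbers for weaker inhibition), compound 1 `O=c1ccc(CCOCc2ccccc2)nn1Cc1ccccc1` gives 32300 nM. Compound 2 `O=c1ccc(CCCOCc2ccccc2)nn1Cc1ccccc1` gives 32500 nM in this assay, a number that lies within the scatter of that of compound 1. Compound 3 `O=c1ccc(CCCO)nn1Cc1ccccc1` differs from compound 2 by hydrogen in place of benzyl on an oxygen on a saturated carbon. Going by the values given here, no step between measured compounds is recorded, so nothing measured shows what this change does. A step toward weaker inhibition, or none beyond the scatter, is expected, read as a 1.7-fold higher number from compound 2 to compound 3 (0.23 log units; within the scatter). Compound 3 is therefore estimated at 55000 nM, with a range from 15000 nM to 200000 nM.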

Compound 3, half-maximal inhibitory concentration: > 100000 nM
Compound 3: no number, only a limit; the forecaster's own chance of this, stated with the estimate: 40%; middle value at least 1.8-fold (0.25 log units) away from the limit.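

Compound 3 gives a limit in this assay and not a number: the limit of > 100000 nM in this assay, at which 1 of the 3 values shown sits.

Hydrogen in place of benzyl on the oxygen gives an at least 3.0-fold higher number from compound 2 to compound 3 (0.48 log units; beyond the scatter), so the benzyl on this oxygen counts toward the weak inhibition, which the two earlier compounds could not show. Hydroxymethyl in place of benzyloxy points the same way, with an at least 3.0-fold higher number from compound 1 to compound 3 (0.49 log units; beyond the scatter).

As far as these compounds go, the full size of the loss stays open. From the compounds shown here alone, whether a methyl ether, an amine or a carboxylic acid at this chain end would keep the inhibition of compound 2 in this assay also remains open.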